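This account rests on a few compounds, and the source may have more. Where it says the series, first, only, none or still open, it means among the compounds named here.

Compound 1 `COc1cc(/C=C/C(=O)c2sc(Nc3ccc(Cl)cc3)nc2C)cc(OC)c1OC` is the starting point of this note, assessed in a functional assay on PC-3 cells (Homo sapiens) for cytotoxicity, read by MTT assay; a higher number here means a weaker inhibitor, a lower number a stronger inhibitor. In this assay compound 1 returns only a limit and not a number, > 25000 nM. Compound 2 `Cc1ccccc1Nc1nc(C)c(C(=O)/C=C/c2ccc(Cl)cc2)s1` likewise gives a limit in this assay, > 25000 nM. Among the compounds with values here, compound 3 `Cc1nc(Nc2ccc(Cl)c(Cl)c2)sc1C(=O)/C=C/c1ccccc1` is the one member with a number in this assay, 7990 nM. Within the data shown here, compound 1 therefore sits at the limit of > 25000 nM in this assay, at which 2 of the 3 values shown sit, and no measured step in this assay connects it to another member. Compound 4 `COc1cc(/C=C/C(=O)c2sc(Nc3ccc(C)cc3)nc2C)cc(OC)c1OC` differs from compound 1 by methyl in place of chloro on an aromatic carbon. Among the measured compounds shown here, with no measured step to build on, no shift beyond the scatter is expected, and the expected step is a number no higher from compound 1 to compound 4 (the limit leaves the size open). Compound 4 is accordingly estimated at 25000 nM in this assay, within 8000 nM to 60000 nM, most likely again reported as a limit.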

Compound 4, half-maximal inhibitory concentration: > 25000 nM
Compound 4: only a limit was reported; the forecaster's own chance of this, stated with the estimate: 65%; the middle value sits exactly at the limit.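

Compound 1 and compound 4 both return only limits in this assay, so no step between them can be read: the limit of > 25000 nM in this assay, at which 3 of the 4 values shown sit.

The compounds shown leave open whether methyl in place of chloro shifts the read-out at all on the core of compound 1.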